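This account rests on a few compounds, and the source may have more. Where it says the series, first, only, none or still open, it means among the compounds named here.

Working notes on the series. Compound 1 `COc1ccc(-c2cccc(C(=O)N(C)C)c2)cc1S(=O)(=O)Nc1cccc(NCCCNC(=O)c2cccc(C)c2)c1` gives in a functional assay on CHO-RD-HGA16 cells for agonist activity at Orexin/Hypocretin receptor type 1 (Homo sapiens), read by fluorescence and calcium flux, with a stated time of 30 min (a higher number here means that more compound is needed for the effect, a lower number that less compound is needed), a value of 400 nM. Compound 2 `COc1ccc(-c2cccc(C(=O)N(C)C)c2)cc1S(=O)(=O)Nc1cccc(NCC(C)NC(=O)c2cccc(C)c2)c1` gives 666 nM. Among the compounds with values here, the only measured pair differing in one place is the chain change a 1.7-fold higher number from compound 1 to compound 2 (0.22 log units; within the scatter). Compound 3 `COc1ccc(-c2ccnc(C(=O)N(C)C)c2)cc1S(=O)(=O)Nc1cccc(NCCNC(=O)c2cccc(C)c2)c1` gives 5170 nM, the highest number of the three, beyond the scatter from compound 2 and further still from compound 1. Compound 4 `COc1ccc(-c2csc(C(=O)N(C)C)n2)cc1S(=O)(=O)Nc1cccc(NCCNC(=O)c2cccc(C)c2)c1` differs from compound 3 by 2-(dimethylcarbamoyl)-1,3-thiazol-4-yl in place of 2-(dimethylcarbamoyl)pyridin-4-yl on an aromatic carbon. Within the data shown here, no measured pair covers this ring exchange on the shared core; the single measured step, a 1.7-fold higher number from compound 1 to compound 2 (0.22 log units; within the scatter), concerns the chain rather than this ring and lies within the scatter, so it offers no direction for the new step. Compound 3 stands alone with its higher number, and nothing measured says whether the exchange moves it. For compound 4 in this assay the expected step of a 1.0-fold lower number from compound 3 to compound 4 (0.01 log units; within the scatter) is none beyond the scatter, held with wide uncertainty. The estimate for compound 4 is 5000 nM, within a range from 1500 nM to 17000 nM.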

Compound 4, half-maximal effective concentration: 928 nM
For compound 4 the middle estimate is 5.4-fold (0.73 log units) above the measured one; measured number below the stated range.
By their numbers in this assay, from the lowest: compounds 1, 2 and 4 (each within the scatter of the next, the first and the last beyond it); then compound 3.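

At the aromatic carbon para to the methoxy group, the choice of ring carrying the dimethylcarbamoyl group changes the reading in this assay: 2-(dimethylcarbamoyl)-1,3-thiazol-4-yl in place of 2-(dimethylcarbamoyl)pyridin-4-yl gives a 5.6-fold lower number from compound 3 to compound 4 (0.75 log units; beyond the scatter). The only earlier step, on the chain, lay within the scatter, so this is the first change in one place shown to move the number beyond it, and the first information on this position. Nothing measured accounts for the step, so its origin stays unassigned.

Going by these compounds, whether the same ring exchange gives a step of similar size with the chain of compound 1 remains open. Also open, on these data alone, is how the number responds on the 1,3-thiazole to a carboxylic acid or a primary amide in place of the dimethylcarbamoyl group.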